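A few compounds are considered here, and "the series" means these few. Any claim that something is new, unique, unknown or untested is made for them only; others in the source may bear on it.

Measured so far in a functional assay on HCT-116 cells (Homo sapiens) for inhibition, read by sulforhodamine B assay, with a stated time of 72 h; on this read-out lower numbers stand for stronger inhibition and higher numbers for weaker inhibition:
compound 1 `COc1ccc2cc(C(C)c3nnc4n3N=C(c3ccc([N+](=O)[O-])cc3)CS4)ccc2c1` gives 15100 nM;
compound 2 `COc1ccc2cc(C(C)c3nnc4n3N=C(c3ccc(C(F)(F)F)cc3)CS4)ccc2c1` gives 10800 nM;
compound 3 `CC(C)Cc1ccc(C(C)c2nnc3n2N=C(c2ccc([N+](=O)[O-])cc2)CS3)cc1` gives "not active" (no number reported), with no number.

Compound 4 `CC(C)Cc1ccc(C(C)c2nnc3n2N=C(c2ccc(C(F)(F)F)cc2)CS3)cc1` is not yet measured. Compound 2 differs from compound 1 by trifluoromethyl in place of nitro on an aromatic carbon, and that change gives a 1.4-fold lower number from compound 1 to compound 2 (0.15 log units; within the scatter). Compound 4 differs from compound 3 in the same way, (trifluoromethyl in place of nitro on an aromatic carbon), and the two place descriptions match word for word. Among the compounds with values here, the difference between the core of compound 3 and the core of compound 1 is not broken down here; what is seen is only that compound 1 gives a number while compound 3 gives none. For compound 4 the step from compound 3 is expected to be small, because a 1.4-fold lower number from compound 1 to compound 2 (0.15 log units; within the scatter) lies within the scatter. Compound 4 is therefore expected at about 45000 nM, between 15000 nM and 150000 nM, with a real chance that again no number is reported.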

Compound 4, half-maximal inhibitory concentration: 6500 nM
Beside the measured number, compound 4's estimate is 6.9-fold (0.84 log units) above it; the measured number lies below the stated range.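

In this assay, within the data shown here, compound 4 gives 6500 nM while compound 3 has no number, so no step between them can be read. What trifluoromethyl in place of nitro does on the core of compound 3 stays open, and no measurement shown bears on this result.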